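A few compounds are considered here, and "the series" means these few. Any claim that something is new, unique, unknown or untested is made for them only; others in the source may bear on it.

Of the compounds shown here, two that share a core have been tested in an assay on isolated protein (Bos taurus) with 5-hydroxytryptamine receptor 1D (Homo sapiens) as the target; a lower number here means a stronger inhibitor, a higher number a weaker inhibitor. Compound 1 `c1ccc2c(c1)CCC(CNCCCCCNC1=NCCCN1)O2` gives 10 nM in this assay. Compound 2 `c1cnc(NCCCNCC2CCc3ccccc3O2)nc1` gives 1.59 nM in this assay, the lower of the two numbers; compound 1 sits well above it, and the gap between the two is larger than the scatter of repeated measurements, so compound 2 is the stronger inhibitor of the pair.

Compound 3 `c1ccc2c(c1)CCC(CNCCCNc1nccs1)O2` differs from compound 2 in one place: 1,3-thiazol-2-yl in place of pyrimidin-2-yl on an amine nitrogen. The rest of the molecule is unchanged. Among the compounds with values here, no pair of measured compounds shows this kind of exchange, so no measured step can be drawn on, and the expectation rests on the value of compound 2 alone. Starting from the number that compound 2 gives in this assay, the expected step of a 2.0-fold higher number from compound 2 to compound 3 (0.30 log units; within the scatter) is a modest one, towards a somewhat higher number, and it may well stay within the scatter. Compound 3 is therefore estimated at 3.2 nM, with a range from 1 nM to 10 nM.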

Compound 3, half-maximal inhibitory concentration: 7.94 nM
Beside the measured number, compound 3's estimate is 2.5-fold (0.39 log units) below it, within the range that was stated.
By their numbers in this assay, from the lowest: compound 2; then compounds 3 and 1 (each within the scatter of the next).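

In this assay the exchange of pyrimidin-2-yl for 1,3-thiazol-2-yl on an amine nitrogen gives a 5.0-fold higher number from compound 2 to compound 3 (0.70 log units; beyond the scatter) and so shows that the number responds to which aromatic ring sits at this position. The two groups match in several counts, with no hydrogen-bond donors, the same number of acceptors, two hetero atoms in the ring and no net charge, so these matching counts alone do not keep the number in place; what differs is the ring size, six-membered against five-membered, and the sulfur that enters. Nothing measured here explains why this exchange raises the number.

On these data alone, whether the higher number goes with the smaller ring or with the sulfur stays open, and a 1,3-oxazol-2-yl group, with oxygen where the thiazole has sulfur, or a pyridin-2-yl group on the same amine nitrogen would help to separate the two. Also open, as far as these compounds go, is whether this exchange would give a step of similar size on a longer chain, since this single pair shows it on one chain only.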